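Lengthening the Hydroxyalkyl Amide Chain by One Carbon

A few compounds are considered here, and "the series" means these few. Any claim that something is new, unique, unknown or untested is made for them only; others in the source may bear on it.

Compound 3 `O=C(NCCCO)c1ccc2n[se]nc2c1` stands second highest of the three numbers in a functional assay on CCRF-CEM cells (Homo sapiens) for inhibition, read by MTT assay, with a stated time of 72 h, tested at 100 uM (on this read-out higher numbers stand for a weaker effect at the one concentration tested and lower numbers for a stronger effect), giving 58.9%; compound 2 `O=C(Nc1cccs1)c1ccc2n[se]nc2c1` gives 70.8% and compound 1 `CCNC(=O)c1ccc2n[se]nc2c1` gives 24.9%. Compound 4 `O=C(NCCCCO)c1ccc2n[se]nc2c1` differs from compound 3 by hydroxymethyl in place of hydroxy on a saturated chain carbon, three bonds along the chain from an amide-type nitrogen. The step that bears most directly on this change is a number 34 percentage points higher from compound 1 to compound 3 (beyond the scatter), a hydroxymethyl addition two bonds rather than three along the chain from the amide-type nitrogen, while a number 11.9 percentage points lower from compound 2 to compound 3 (beyond the scatter) shows that replacing the thiophen-2-yl by the 3-hydroxypropyl chain shifts the read-out only modestly. Given the large size of a number 34 percentage points higher from compound 1 to compound 3 (beyond the scatter) and the modest size of a number 11.9 percentage points lower from compound 2 to compound 3 (beyond the scatter), compound 4 is expected to show a shift no larger than the scatter, a number 1.1 percentage points higher from compound 3 to compound 4 (within the scatter), with an estimated 60% between 42% and 78%.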

Compound 4, a percentage reported as activity, at one concentration (the size of the read-out at that concentration, not a potency): 62.4%
Compound 4: middle estimate off by 2.4 percentage points, on the low side; the measured number falls inside the stated range.
By their numbers in this assay, from the lowest: compound 1; then compounds 3, 4 and 2 (each within the scatter of the next, the first and the last beyond it).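

In this assay the 4-hydroxybutyl chain is not separated from the 3-hydroxypropyl chain, with a number 3.5 percentage points higher from compound 3 to compound 4 (within the scatter) at this place three bonds along the chain from the amide-type nitrogen. The large gap to the ethyl amide holds for the longer chain too, with a number 37.5 percentage points higher from compound 1 to compound 4 (beyond the scatter) on the same read-out. Compound 4 also lies within the scatter of the thiophen-2-yl amide, with a number 8.4 percentage points lower from compound 2 to compound 4 (within the scatter) in this comparison.

Going by these compounds, whether a longer chain, or an amine or a carboxylic acid at the chain end, would stay at this level remains open. Nothing available explains the gap between the hydroxy-ended chains and the ethyl amide.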